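The source may hold more compounds than are shown below. What is called first, only, known or untested is meant among the compounds shown, and "the series" means these compounds.

Measured so far:
- compound 1, `Cc1ccc(C2=NN(c3ccc([N+](=O)[O-])cc3)C(c3cn(-c4ccccc4)nc3-c3ccc(Cl)c(Cl)c3)C2)cc1`: 57.4%
- compound 2, `CC(=O)N1N=C(c2ccc(Cl)cc2)CC1c1cn(-c2ccccc2)nc1-c1ccc(Cl)c(Cl)c1`: 45.7%
- compound 3, `O=[N+]([O-])c1ccc(N2N=C(c3ccc(F)cc3)CC2c2cn(-c3ccccc3)nc2-c2ccc(Cl)c(Cl)c2)cc1`: 45.7%

In a functional assay on the whole organism (strain Wistar) for inhibition, with Rattus norvegicus as the target, read by paw edema, with a stated time of 30 min, at a dose of 50 mg/kg by the oral route (a higher number here means more inhibition at the dose given (going by the name of the read-out), a lower number less inhibition), compound 3 gives 45.7%, level at the digits printed with compound 2 and together with it the lowest of the three numbers. Going by the values given here, the one step into compound 3 is a number 11.7 percentage points lower from compound 1 to compound 3 (beyond the scatter), a modest fall beyond the scatter.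

Compound 4, `O=[N+]([O-])c1ccc(N2N=C(c3ccc(Cl)cc3)CC2c2cn(-c3ccccc3)nc2-c2ccc(Cl)c(Cl)c2)cc1`, is not yet measured. It differs from compound 3 as follows: chloro in place of fluoro on an aromatic carbon.

Among the compounds with values here, no measured step covers chloro in place of fluoro directly. Within the data shown here, compound 2 carries the 4-chlorophenyl group of compound 4, yet it also differs from compound 3 elsewhere, so its value only shows that a 4-chlorophenyl analogue can sit at the same level as compound 3; no step between compound 2 and compound 3 is given. Among the measured compounds shown here, the only halogen-related step, a number 11.7 percentage points lower from compound 1 to compound 3 (beyond the scatter), went from methyl to fluoro and bears on this change only loosely. The expectation is therefore a step of a number 4.3 percentage points higher from compound 3 to compound 4 (within the scatter), within the scatter, with a slight upward lean. Compound 4 is estimated at 50%, with a range from 40% to 62%.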

Compound 4, a percentage reported as inhibition, in the whole organism at one dose (the size of the read-out at that dose, not a potency): 48.9%
Compound 4: the middle estimate sits 1.1 percentage points above what was measured; the measured number falls inside the stated range.
By their numbers in this assay, from the lowest: compounds 2, 3, 4 and 1 (each within the scatter of the next, the first and the last beyond it).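

In this assay, the change from 4-fluorophenyl to 4-chlorophenyl gives a number 3.2 percentage points higher from compound 3 to compound 4 (within the scatter), so fluoro and chloro para to a large group are not told apart at this dose. Starting from methyl at the same place, chloro gives a number 8.5 percentage points lower from compound 1 to compound 4 (within the scatter) and fluoro gives a number 11.7 percentage points lower from compound 1 to compound 3 (beyond the scatter), so only the fluoro step clears the scatter, although the two halogens themselves remain inseparable. With the 4-chlorophenyl group held, 4-nitrophenyl in place of acetyl on the amine nitrogen in a ring gives a number 3.2 percentage points higher from compound 2 to compound 4 (within the scatter), so these two substituents are not separated either.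

As far as these compounds go, whether a methoxy group or an amine at the para place would move the number beyond the scatter from chloro remains open. Nothing at hand explains these numbers or shows how they would hold at other doses or times.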